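Group swap from compound 3 to compound 4: working notes

A few compounds are considered here, and "the series" means these few. Any claim that something is new, unique, unknown or untested is made for them only; others in the source may bear on it.

Measured in an ADME assay on Vero cells (Chlorocebus sabaeus) for cytotoxicity, with a stated time of 7 days; a lower number here means that less compound is tolerated, a higher number that more compound is tolerated:
compound 1 `COc1ccc2[nH]c(C(=O)N3CC(=O)N(Cc4ccccc4)[C@@H](CCc4ccccc4)C3)cc2c1` gives > 30000 nM (a limit of the assay, not a number)
compound 2 `COc1ccc2[nH]c(C(=O)N3CC(=O)N(Cc4ccccc4)[C@@H](CN4CCC5(CC4)CC5)C3)cc2c1` gives 17100 nM
compound 3 `COc1ccc2[nH]c(C(=O)N3CC(=O)N(Cc4ccccc4)[C@@H](CN4C(=O)c5ccccc5C4=O)C3)cc2c1` gives 41000 nM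

Compound 3 holds the higher of the two exact numbers, and compound 2 is its nearest neighbour, with a 2.4-fold higher number from compound 2 to compound 3 (0.38 log units; beyond the scatter). The value of compound 1 is a limit, so it cannot be placed in order with them.

Compound 4 `COc1ccc2[nH]c(C(=O)N3CC(=O)N(Cc4ccccc4)[C@@H](CN4CCC5(CCCC5)CC4)C3)cc2c1` is still to be measured. The change is a group of 10 heavy atoms (9 carbon, 1 nitrogen; one five-membered non-aromatic ring of carbon only, one six-membered non-aromatic ring with 1 hetero atom) in place of a group of 11 heavy atoms (8 carbon, 1 nitrogen, 2 oxygen; one five-membered non-aromatic ring with 1 hetero atom, one six-membered aromatic ring of carbon only), on a saturated chain carbon bound to a saturated ring carbon.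

The entering group shares its six-membered non-aromatic ring with 1 hetero atom with the group in compound 2, but has a five-membered non-aromatic ring of carbon only where compound 2 has a three-membered one. The closest evidence is therefore a 2.4-fold higher number from compound 2 to compound 3 (0.38 log units; beyond the scatter), read here in reverse. The other two steps add little: an at least 1.7-fold lower number from compound 1 to compound 2 (0.24 log units; that floor lies within the scatter) and a step that the limit leaves unreadable from compound 1 to compound 3.

On compound 2 and its 17100 nM, a number near that of compound 2 is expected in this assay. The expected change is a 2.9-fold lower number from compound 3 to compound 4 (0.47 log units; beyond the scatter), a modest step to a lower number. For compound 4 the estimate is 14000 nM, with an expected range of 6000 nM to 30000 nM.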

Compound 4, half-maximal cytotoxic concentration: 3600 nM
Beside the measured number, compound 4's estimate is 3.9-fold (0.59 log units) above it; the whole stated range lies above it.
By their numbers in this assay, from the lowest: compound 4; then compound 2; then compound 3.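

In this assay, the place on a saturated chain carbon bound to a saturated ring carbon now shows a large step, an 11-fold lower number from compound 3 to compound 4 (1.06 log units; beyond the scatter), as the group with the five-membered non-aromatic ring with 1 hetero atom and the six-membered aromatic ring of carbon only gives way to the group with the five-membered non-aromatic ring of carbon only and the six-membered non-aromatic ring with 1 hetero atom. The six-membered non-aromatic ring with 1 hetero atom is common to the two groups in the next step, so a difference in the ring of carbon only, five-membered against three-membered, is enough for a change beyond the scatter: a 4.8-fold lower number from compound 2 to compound 4 (0.68 log units; beyond the scatter). The remaining step, an at least 8.3-fold lower number from compound 1 to compound 4 (0.92 log units; beyond the scatter), starts from a limit of the assay, not a number, and so reads only as a floor: the limit of > 30000 nM in this assay, at which 1 of the 4 values shown sits.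

Two sizes of the ring of carbon only cannot show whether the number in this assay falls steadily with ring size, and a four-membered or six-membered ring of carbon only would test that. On these data alone, it also remains open how a hydroxyl group or a carboxylic acid on the five-membered ring of carbon only would read in this place.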